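Extending the Chain on the Aromatic Carbon

The compounds below may be only part of what the source reports. "The series", "measured", "known", "first", "only" and "open" are said of these compounds alone.

Measured so far:
compound 1 `CCc1ccc(NC(=O)N[C@H](C)c2ccccc2)cc1` gives 47%
compound 2 `C[C@@H](NC(=O)Nc1ccc(C(C)(C)C)cc1)c1ccccc1` gives 88%
compound 3 `CCCCCCc1ccc(NC(=O)N[C@H](C)c2ccccc2)cc1` gives 101%

In an ADME assay on the whole organism with Oryza sativa as the target, tested at 1 uM (on this read-out lower numbers stand for a stronger effect and higher numbers for a weaker effect at the one concentration tested), compound 3 stands highest of the three numbers, with compound 2 nearest and compound 1 furthest. Compound 4 `CCCCCCCc1ccc(NC(=O)N[C@H](C)c2ccccc2)cc1` differs from compound 3 by methyl in place of hydrogen on a saturated chain carbon, six bonds along the chain from an aromatic carbon. Going by the values given here, three measured steps bear on this: a number 41 percentage points higher from compound 1 to compound 2 (beyond the scatter), a number 54 percentage points higher from compound 1 to compound 3 (beyond the scatter), and a number 13 percentage points higher from compound 2 to compound 3 (beyond the scatter). Each of these enlarged the group on the aromatic carbon and raised the number, the last one only modestly. Compound 4 is therefore expected to show a small rise or none beyond the scatter, a number 4 percentage points higher from compound 3 to compound 4 (within the scatter). Compound 4 is estimated at 105%, with a range from 92% to 118%.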

Compound 4, a percentage reported as activity, at one concentration (the size of the read-out at that concentration, not a potency): 100%
Estimate against measurement, compound 4: 5 percentage points above, and the stated range covers the measured number.
By their numbers in this assay, from the lowest: compound 1; then compound 2; then compounds 4 and 3 (each within the scatter of the next).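

In this assay methyl in place of hydrogen, six bonds along the chain from an aromatic carbon, gives a number 1 percentage points lower from compound 3 to compound 4 (within the scatter) and so the climb seen with the earlier enlargements does not continue at this chain length. Heptyl still stands clear of the smaller groups, with a number 12 percentage points higher from compound 2 to compound 4 (beyond the scatter) and a number 53 percentage points higher from compound 1 to compound 4 (beyond the scatter) as the steps that show it. Nothing available explains why the number levels off here. As far as these compounds go, whether a longer chain such as octyl stays level remains open, as does whether a chain ending in a hydroxyl group, an amine or a carboxylic acid would bring the number down.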